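Replacing 4-chlorophenyl with 3-methoxyphenyl in compound 1

The source may report more compounds than this note shows. Statements on the series, on what has been measured and on what is new or still open speak of the compounds shown alone.

In an ADME assay on NHDF cells (Homo sapiens) for cytotoxicity, read by MTT assay, with a stated time of 72 h (a lower number here means a stronger inhibitor, a higher number a weaker inhibitor), compound 1 (`COc1cccc(/C=C2\CCC/C(=C\c3ccc(Cl)cc3)C2=O)c1OC`) gives 18600 nM as its value, and compound 2 (`COc1ccccc1/C=C1\CCC/C(=C\c2cccc(OC)c2OC)C1=O`) gives 31300 nM as its value. The gap is a 1.7-fold higher number from compound 1 to compound 2 (0.23 log units; within the scatter) and so gives compound 1 no clear place of its own on these two numbers.

Compound 3 (`COc1cccc(/C=C2\CCC/C(=C\c3cccc(OC)c3OC)C2=O)c1`) has not yet been measured. Its difference from compound 1 is 3-methoxyphenyl in place of 4-chlorophenyl on a double-bonded chain carbon bound to a double-bonded ring carbon and consists of 3-methoxyphenyl in place of 4-chlorophenyl on a double-bonded chain carbon bound to a double-bonded ring carbon.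

Going by the values given here, only one measured step bears on this change. In compound 2, 2-methoxyphenyl stands in place of 4-chlorophenyl at that same place, and the result was a 1.7-fold higher number from compound 1 to compound 2 (0.23 log units; within the scatter) in this assay for that exchange. Among the compounds with values here, no measurement yet covers 3-methoxyphenyl itself, so this step is only a guide. The expected step is a 1.5-fold higher number from compound 1 to compound 3 (0.18 log units; within the scatter) and it is estimated to stay within the scatter. The value estimated for compound 3 is 28000 nM with an expected range of 14000 nM to 55000 nM overall.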

Compound 3, half-maximal inhibitory concentration: 16400 nM
Estimate against measurement, compound 3: 1.7-fold (0.23 log units) above; the measured number falls inside the stated range.
By their numbers in this assay, from the lowest: compounds 3, 1 and 2 (each within the scatter of the next).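

In this assay the exchange of 4-chlorophenyl for 3-methoxyphenyl, on a double-bonded chain carbon bound to a double-bonded ring carbon, gives a 1.1-fold lower number from compound 1 to compound 3 (0.05 log units; within the scatter) and therefore no readable change, even though the entering group carries an oxygen and a hydrogen-bond acceptor that 4-chlorophenyl lacks. Going by these compounds alone, the two methoxyphenyl groups also cannot be told apart at this place, since a 1.9-fold lower number from compound 2 to compound 3 (0.28 log units; within the scatter) is the step between them, which shows for the first time that moving from 2-methoxyphenyl to 3-methoxyphenyl leaves the number within the scatter. All three groups seen at this place, 4-chlorophenyl, 2-methoxyphenyl and 3-methoxyphenyl, thus give numbers that do not separate from one another, and no measurement at hand speaks to what lies behind this.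

Going by these compounds, all three groups are substituted phenyl rings, so it remains open whether a group of another kind at this place, such as an amine, a carboxylic acid or a longer chain, would move the number beyond the scatter. The compounds also leave open whether this flat picture would hold if the rest of the shared core were changed.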